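The source may report more compounds than this note shows. Statements on the series, on what has been measured and on what is new or still open speak of the compounds shown alone.

All three measured compounds were tested in a functional assay on CCRF-CEM cells (Homo sapiens) for cytotoxicity; on this read-out lower numbers stand for stronger inhibition and higher numbers for weaker inhibition:

compound 1, `Cc1ccc(NC(=O)/C=C/C(=O)N2C/C(=C\c3ccccc3)C(=O)/C(=C/c3ccccc3)C2)cc1`, 1100 nM
compound 2, `CC(=O)c1ccc(NC(=O)/C=C/C(=O)N2C/C(=C\c3ccccc3)C(=O)/C(=C/c3ccccc3)C2)cc1`, 1700 nM
compound 3, `O=C(/C=C/C(=O)N1C/C(=C\c2ccc([N+](=O)[O-])cc2)C(=O)/C(=C/c2ccc([N+](=O)[O-])cc2)C1)Nc1ccc(Cl)c(Cl)c1`, 380 nM

Compound 3 shows the lowest number of the three. Compound 1 is nearest to it and compound 2 furthest, and both gaps are beyond the scatter of repeated measurements, so compound 3 stands as the strongest inhibitor among the measured compounds. Compound 4, `O=C(/C=C/C(=O)N1C/C(=C\c2ccc([N+](=O)[O-])cc2)C(=O)/C(=C/c2ccc([N+](=O)[O-])cc2)C1)Nc1ccc(Cl)cc1`, has not yet been measured. It differs from compound 3 in one place: hydrogen in place of chloro on an aromatic carbon. Going by the values given here, the only measured step between compounds differing in one place is a 1.5-fold higher number from compound 1 to compound 2 (0.19 log units; within the scatter), and that step swaps a different group elsewhere in the molecule; compounds 1 and 2 also carry a different core from compound 3. Among the compounds with values here, no measured step speaks to a chloro leaving this ring. The step from compound 3 to compound 4 in this assay is expected to be a 1.4-fold higher number from compound 3 to compound 4 (0.16 log units; within the scatter), a modest rise of the number that need not exceed the scatter. Compound 4 is therefore estimated at 550 nM, within a range from 250 nM to 1200 nM.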

Compound 4, half-maximal inhibitory concentration: 810 nM
Compound 4: the middle estimate sits 1.5-fold (0.17 log units) below what was measured; the measured number falls inside the stated range.
By their numbers in this assay, from the lowest: compound 3; then compounds 4, 1 and 2 (each within the scatter of the next, the first and the last beyond it).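

Taking one chloro off the ring, so that the 3,4-dichlorophenyl group becomes a 4-chlorophenyl group, gives in this assay a 2.1-fold higher number from compound 3 to compound 4 (0.33 log units; beyond the scatter), a modest change but a real one. Going by these compounds alone, the only step measured before it lay within the scatter and at a different place, so this is the first sign that a single substituent on these compounds can shift the cytotoxicity read-out beyond the scatter: here, the chloro that sits ortho to the other chloro. No supporting data explain why the loss of this one heavy atom has an effect of this size.

On these data alone, whether another group at this position, such as fluoro, methoxy or an amine, would serve as well as chloro remains open. So does whether the same change would have the same effect on the core of compound 1, or what would follow if the remaining chloro also gave way to hydrogen.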